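Working notes: from compound 2 to compound 3

This account rests on a few compounds, and the source may have more. Where it says the series, first, only, none or still open, it means among the compounds named here.

Measured in a functional assay on KB 3-1 cells (Homo sapiens) for cytotoxicity, read by MTT assay, with a stated time of 72 h; a higher number here means a weaker inhibitor, a lower number a stronger inhibitor:
- compound 1 `O=C1Nc2ccccc2/C1=N/NC(=S)NC1CCCCC1`: 9140 nM
- compound 2 `CNC(=S)N/N=C1\C(=O)Nc2ccccc21`: 35300 nM

Compound 2 has the higher of the two numbers in this assay. Compound 3 `O=C1Nc2ccccc2/C1=N/NC(=S)Nc1cccc(Cl)c1` carries 3-chlorophenyl in place of methyl on an amide-type nitrogen. Going by the values given here, the only measured step at this nitrogen is a 3.9-fold higher number from compound 1 to compound 2 (0.59 log units; beyond the scatter), with methyl replacing cyclohexyl. No aromatic group has been measured there yet. Read in reverse, that single step points to a modest expected fall in this assay, beyond the scatter. The estimated change is a 3.9-fold lower number from compound 2 to compound 3 (0.59 log units; beyond the scatter). The expected value for compound 3 is 9000 nM, within an estimated range of 3000 nM to 25000 nM.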

Compound 3, half-maximal inhibitory concentration: 1870 nM
Compound 3: the middle estimate sits 4.8-fold (0.68 log units) above what was measured, and the stated range ends above it.
By their numbers in this assay, from the lowest: compound 3; then compound 1; then compound 2.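

In this assay, going by these compounds alone, 3-chlorophenyl on the amide-type nitrogen gives the largest step at this position so far, with a 19-fold lower number from compound 2 to compound 3 (1.28 log units; beyond the scatter) and also a 4.9-fold lower number from compound 1 to compound 3 (0.69 log units; beyond the scatter) as the step over cyclohexyl. Group size alone therefore does not settle the order here: cyclohexyl and 3-chlorophenyl, both larger than methyl, stand apart beyond the scatter. Nothing available accounts for this difference.

On these data alone, whether the gain belongs to the aromatic ring or to its chlorine remains open, and phenyl without chlorine would separate the two. As far as these compounds go, the outcome with benzyl or pyridyl on this nitrogen is also open.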